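A few compounds are considered here, and "the series" means these few. Any claim that something is new, unique, unknown or untested is made for them only; others in the source may bear on it.

In a functional assay on K562 cells (Homo sapiens) for antiproliferative activity, read by CCK-8 assay, with a stated time of 24 h (on this read-out higher numbers stand for weaker inhibition and lower numbers for stronger inhibition), compound 1 `Cc1ccc(NC(=O)c2ccc(CN3CCCN(C)CC3)cc2)cc1-n1cc(-c2cnc3ccnn3c2)cn1` gives 5880 nM. In this assay compound 2 `COc1ccc(C(=O)Nc2ccc(C)c(-n3cc(-c4cnc5ccnn5c4)cn3)c2)cc1` gives 19700 nM, the higher of the two numbers shown, set apart from compound 1 by the step of a 3.4-fold higher number from compound 1 to compound 2 (0.53 log units; beyond the scatter). Compound 3 `Cc1ccc(NC(=O)c2ccc(C(F)(F)F)cc2)cc1-n1cc(-c2cnc3ccnn3c2)cn1` differs from compound 2 by trifluoromethyl in place of methoxy on an aromatic carbon. Among the compounds with values here, the single measured step concerns a different exchange at the same place and does not cover this one, so it offers no direct guide. The expected step is therefore small, a 1.3-fold lower number from compound 2 to compound 3 (0.12 log units; within the scatter), in neither direction beyond the scatter. Compound 3 is expected to give about 15000 nM, between 5000 nM and 45000 nM.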

Compound 3, half-maximal inhibitory concentration: 6930 nM
Compound 3: middle estimate off by 2.2-fold (0.34 log units), on the high side, within the range that was stated.
By their numbers in this assay, from the lowest: compounds 1 and 3 (each within the scatter of the next); then compound 2.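

In this assay, this position proves sensitive even to an exchange between two small groups with no ring, as trifluoromethyl in place of methoxy gives a 2.8-fold lower number from compound 2 to compound 3 (0.45 log units; beyond the scatter) and so moves the number beyond the scatter. Trifluoromethyl also stands level with the ring-bearing (4-methyl-1,4-diazepan-1-yl)methyl group, with a 1.2-fold higher number from compound 1 to compound 3 (0.07 log units; within the scatter) and thus no difference beyond the scatter, so that larger group is not needed to reach this level here. No measurement available here explains either result.

On these data alone, whether a smaller group such as a nitrile or a chlorine atom would match trifluoromethyl remains open. So does whether a carboxylic acid or a simple open-chain amine at this position would give a clearly lower number.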